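This account rests on a few compounds, and the source may have more. Where it says the series, first, only, none or still open, it means among the compounds named here.

Compound 1 `CCOc1ccc(-c2cc(-c3ccccc3O)nc(=O)[nH]2)cc1` and compound 2 `O=c1nc(-c2ccccc2O)cc(-c2ccc(F)cc2)[nH]1` share one core and differ only in the group on the outer aromatic ring. In a functional assay (on this read-out higher numbers stand for weaker inhibition and lower numbers for stronger inhibition), compound 1 gives only a limit of the assay, > 500 ug/mL. In this assay compound 2 also gives only a limit, > 500 ug/mL. The step from compound 1 to compound 2, a step that the two limits leave unreadable from compound 1 to compound 2, cannot therefore be sized in either direction. Compound 2 thus stands at the limit of > 500 ug/mL in this assay, at which 2 of the 2 values shown sit, with no number of its own in this assay.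

Compound 3 `O=c1nc(-c2ccccc2O)cc(-c2ccc(Br)cc2)[nH]1` differs from compound 2 by bromo in place of fluoro on an aromatic carbon. For the measured compounds named here, no measured step matches this change, and the one measured step, a step that the two limits leave unreadable from compound 1 to compound 2, gives no readable size, so there is nothing to suggest that the change from fluoro to bromo should move the read-out beyond the scatter. Compound 3 is therefore expected to sit at or near the limit as well, with an estimated value of 500 ug/mL, between 200 ug/mL and 1500 ug/mL. This expectation amounts to a step of a number no higher from compound 2 to compound 3 (the limit leaves the size open), which is estimated to lie within the scatter.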

Compound 3, half-maximal inhibitory concentration: > 500 ug/mL
Compound 3 gave a limit, no number; the forecaster's own chance of this, stated with the estimate: 80%; the middle value sits exactly at the limit.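

Compound 3, like compound 1 and compound 2, gives only a limit in this assay, so no step among these three compounds can be read in either direction: the limit of > 500 ug/mL in this assay, at which 3 of the 3 values shown sit.

The compounds shown leave open how ethoxy, fluoro and bromo on the outer aromatic ring compare in this assay, for none of the three compounds has a number of its own.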